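Amino for hydroxy, carried from one core to the other

This account rests on a few compounds, and the source may have more. Where it says the series, first, only, none or still open, it means among the compounds named here.

Compound 1 `COc1ccc(-c2ssc(=S)c2-c2cc(OC)c(OC)c(OC)c2)cc1O` and compound 2 `COc1ccc(-c2ssc(=S)c2-c2cc(OC)c(OC)c(OC)c2)cc1N` share a core and differ by amino in place of hydroxy on an aromatic carbon. In a functional assay on SGC-7901 cells (Homo sapiens) for antiproliferative activity, read by MTT assay, with a stated time of 72 h (a higher number here means a weaker inhibitor, a lower number a stronger inhibitor), compound 1 gives 271 nM, and compound 2 gives 444 nM; the step is a 1.6-fold higher number from compound 1 to compound 2 (0.21 log units; within the scatter).

Compound 3 `COc1ccc(-c2ss/c(=N/O)c2-c2cc(OC)c(OC)c(OC)c2)cc1O` is built on a second core; the difference between the two cores is not broken down here. In this assay compound 3 gives 200 nM, within the scatter of compound 1 and beyond it only against compound 2.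

Compound 4 `COc1ccc(-c2ss/c(=N/O)c2-c2cc(OC)c(OC)c(OC)c2)cc1N` repeats the change on the core of compound 3: amino in place of hydroxy on an aromatic carbon. The place is described in the same words as for the first pair, so this is the same change, measured once so far. Among the measured compounds shown here, the step from compound 3 to compound 4 is expected to be a 1.6-fold higher number from compound 3 to compound 4 (0.20 log units; within the scatter) because the one measured instance gave a 1.6-fold higher number from compound 1 to compound 2 (0.21 log units; within the scatter). With a single precedent, the range is kept wide around that step. Compound 4 is therefore estimated at 320 nM in this assay, expected between 150 nM and 700 nM.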

Compound 4, half-maximal inhibitory concentration: 4300 nM
Compound 4: middle estimate off by 13-fold (1.13 log units), on the low side, outside the stated range (above it).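

On the core of compound 3, the change from 3-hydroxy-4-methoxyphenyl to 3-amino-4-methoxyphenyl is a large step in this assay (a 22-fold higher number from compound 3 to compound 4 (1.33 log units; beyond the scatter)), so a step measured on the core of compound 1 cannot simply be transferred to this core. These two pairs give no reason for the difference, and they do not show how the same change would behave on any third core, or in any other assay. The size of the step therefore depends on the core in these two pairs, and the change is best treated as core-specific in this series: the same change on two cores in this assay, a 1.6-fold higher number (0.21 log units; within the scatter) from compound 1 to compound 2 and a 22-fold higher number (1.33 log units; beyond the scatter) from compound 3 to compound 4, 13-fold (1.12 log units) apart, beyond the scatter of two such steps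

The compounds shown leave open whether the sensitivity of the core of compound 3 is specific to amino or extends to other replacements for hydroxy at this place, such as methylamino, acetamido or fluoro. They also leave open whether a larger replacement, such as a longer alkoxy chain, would follow the same course on both cores.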